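Aromatic carbonyl in place of benzyl on the ring amine

The source may report more compounds than this note shows. Statements on the series, on what has been measured and on what is new or still open speak of the compounds shown alone.

The series is read in an assay on membranes from Cortex for displacement of a labelled ligand from Sigma non-opioid intracellular receptor 1 (Cavia porcellus), read by scintillation counting, with a stated time of 120 min; a lower number here means a stronger inhibitor, a higher number a weaker inhibitor. Compound 1 `Fc1ccc(C(SCCNC2CCN(Cc3ccccc3)CC2)c2ccc(F)cc2)cc1` gives 3.81 nM, compound 2 `Fc1ccc(C(SCCNC2CCN(Cc3ccc(Cl)cc3)CC2)c2ccc(F)cc2)cc1` gives 45.5 nM, and compound 3 `O=C(c1cc2ccccc2[nH]1)N1CCC(NCCSC(c2ccc(F)cc2)c2ccc(F)cc2)CC1` gives 1130 nM. Compound 2 thus stands second highest of the three numbers: its nearest neighbour is compound 1, separated by a 12-fold higher number from compound 1 to compound 2 (1.08 log units; beyond the scatter), and the furthest is compound 3, separated by a 25-fold higher number from compound 2 to compound 3 (1.40 log units; beyond the scatter).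

Compound 4 `O=C(c1ccccc1F)N1CCC(NCCSC(c2ccc(F)cc2)c2ccc(F)cc2)CC1` differs from compound 2 in one place: (2-fluorophenyl)carbonyl in place of 4-chlorobenzyl on an amine nitrogen in a ring. Within the data shown here, no measured step carries this entering group, but two steps exchange a benzyl-type group on the same ring nitrogen for an aromatic carbonyl: a 25-fold higher number from compound 2 to compound 3 (1.40 log units; beyond the scatter) and a 300-fold higher number from compound 1 to compound 3 (2.47 log units; beyond the scatter). Both are large and both run toward a higher number. Among the measured compounds shown here, the entering (2-fluorophenyl)carbonyl is a different aromatic carbonyl from the (1H-indol-2-yl)carbonyl of compound 3, so the earlier steps need not transfer in full size, yet the direction they share is the only guide at hand. A step of about a 13-fold higher number from compound 2 to compound 4 (1.12 log units; beyond the scatter) is therefore expected, toward a weaker inhibitor. For compound 4 the number in this assay is estimated at 600 nM, with a range from 150 nM to 2500 nM.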

Compound 4, inhibition constant: 3.57 nM
The estimate for compound 4 lay 170-fold (2.23 log units) above the measured number, outside the stated range (below it).
By their numbers in this assay, from the lowest: compounds 4 and 1 (each within the scatter of the next); then compound 2; then compound 3.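

In this assay an aromatic carbonyl on the amine nitrogen of the ring does not in itself weaken binding: (2-fluorophenyl)carbonyl in place of 4-chlorobenzyl gives a 13-fold lower number from compound 2 to compound 4 (1.11 log units; beyond the scatter) and is set against a large step, while the same group in place of benzyl gives a 1.1-fold lower number from compound 1 to compound 4 (0.03 log units; within the scatter) and so leaves the two compounds level. Within the carbonyl pair the aromatic group carries the whole difference, with 2-fluorophenyl in place of 1H-indol-2-yl on the carbonyl carbon giving a 320-fold lower number from compound 3 to compound 4 (2.50 log units; beyond the scatter) and tying the high number of compound 3 to the 1H-indol-2-yl group rather than to the carbonyl as such. No measurement accompanies these compounds that could account for this tolerance of the carbonyl.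

Going by these compounds, what the fluorine contributes remains open, and a plain benzoyl group on the ring nitrogen would separate it from the carbonyl itself. On these data alone, whether the chloro step seen among the benzyl compounds carries over to the carbonyl compounds also remains open, a question that a 4-chlorobenzoyl group would address.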